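A few compounds are considered here, and "the series" means these few. Any claim that something is new, unique, unknown or untested is made for them only; others in the source may bear on it.

In a functional assay on the whole organism for inhibition, with Rattus norvegicus as the target (on this read-out higher numbers stand for weaker inhibition and lower numbers for stronger inhibition), compound 1 `O=C1ON=C(c2cccs2)/C1=C/c1ccccc1` gives 4400 nM and compound 2 `CN(C)c1ccc(/C=C2\C(=O)ON=C2c2cccs2)cc1` gives 4200 nM as its value. These two numbers lie within the usual scatter of each other, so compound 2 stands level with compound 1. Compound 3 `O=C(O)COc1ccc(/C=C2\C(=O)ON=C2c2cccs2)cc1` keeps the core of compound 2 and changes one group, with carboxymethoxy in place of dimethylamino on an aromatic carbon. Going by the values given here, only one measured step bears on this spot: putting dimethylamino in place of hydrogen gave a 1.0-fold lower number from compound 1 to compound 2 (0.02 log units; within the scatter) and stayed within the scatter. That single step does not test carboxymethoxy itself, so the forecast stays loose. No step beyond the scatter is expected, in either direction. The expected step is a 1.2-fold higher number from compound 2 to compound 3 (0.08 log units; within the scatter) in this assay as a best guess. Expected for compound 3 is 5000 nM as the value, with an estimated range from 1500 nM to 17000 nM for repeat measurements.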

Compound 3, half-maximal inhibitory concentration: 100000 nM
Compound 3: middle estimate off by 20-fold (1.30 log units), on the low side; measured number outside the range, above it.
By their numbers in this assay, from the lowest: compounds 2 and 1 (each within the scatter of the next); then compound 3.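

In this assay, this spot on the aromatic ring, para to a large group, turns out not to accept every group equally: carboxymethoxy gives a 24-fold higher number from compound 2 to compound 3 (1.38 log units; beyond the scatter), and measured against plain hydrogen it gives a 23-fold higher number from compound 1 to compound 3 (1.36 log units; beyond the scatter), so inhibition is much weaker with it in either comparison. Hydrogen and dimethylamino had stood level here, so the earlier compounds gave no sign that a change at this position could matter so much. Nothing available explains why carboxymethoxy has this effect.

The compounds shown leave open whether the step belongs to the carboxylic acid end of the carboxymethoxy group or to the chain as a whole, which a methoxy group or the matching methyl ester could separate. They also leave open how a primary amine would behave at this position.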